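Swapping chloro for ethoxycarbonyl on the shared core

The source may report more compounds than this note shows. Statements on the series, on what has been measured and on what is new or still open speak of the compounds shown alone.

In a functional assay on MDA-MB-231 cells (Homo sapiens) for antiproliferative activity, with a stated time of 48 h (on this read-out lower numbers stand for stronger inhibition and higher numbers for weaker inhibition), compound 1 (`CCN(CC)c1ccc(-c2cccc(Cl)c2)nn1`) gives > 25000 nM and this is a limit of the assay, not a number. It marks the limit of > 25000 nM in this assay, at which 1 of the 3 values shown sits, and so offers no exact starting point. Compound 4 (`CCOC(=O)c1cccc(-c2ccc(N(CC)CC)nn2)c1`) carries ethoxycarbonyl in place of chloro on an aromatic carbon, meta to a large group (ethoxycarbonyl in place of chloro on an aromatic carbon). For the measured compounds named here, no measured step covers this exchange directly. The nearest evidence comes from compound 2 (`CCN(CC)c1ccc(-c2ccc(C(C)=O)cc2)nn1`) at 5000 nM and compound 3 (`CCOC(=O)c1ccc(-c2ccc(N(CC)CC)nn2)cc1`) at 1500 nM in this assay where both carry a carbonyl group, although at a different place on the ring from compound 4. Going by the values given here, the only measured step is a 3.3-fold lower number from compound 2 to compound 3 (0.52 log units; beyond the scatter) and it exchanges methyl for ethoxy on a carbonyl carbon. Since compound 3 at 1500 nM already carries the ethoxycarbonyl group, a clear move towards stronger inhibition is expected, with some allowance for the different placement. The expected size is an at least 6.2-fold lower number from compound 1 to compound 4 (0.79 log units; beyond the scatter) and it remains a rough estimate. Compound 4 is expected at 4000 nM with an estimated range of 1200 nM to 15000 nM in this measurement.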

Compound 4, half-maximal inhibitory concentration: > 25000 nM
Compound 4: only a limit was reported; the forecaster's own chance of this, stated with the estimate: 12%; middle value at least 6.2-fold (0.79 log units) from the limit.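

Compound 1 and compound 4 both stand at a limit of the assay, so no step between them can be read in this assay: the limit of > 25000 nM in this assay, at which 2 of the 4 values shown sit.

The compounds shown leave open whether ethoxycarbonyl in place of chloro changes the inhibition at all.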